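A few compounds are considered here, and "the series" means these few. Any claim that something is new, unique, unknown or untested is made for them only; others in the source may bear on it.

Compound 1, `Nc1ccccc1NC(=O)c1ccc(COc2ccc3ncnc(Nc4cccc(Br)c4)c3c2)cc1`, is one of two compounds in this study with a result in a functional assay on SK-BR-3 cells (Homo sapiens) for cytotoxicity, read by resazurin assay; a higher number here means a weaker inhibitor, a lower number a stronger inhibitor. In this assay, within the data shown here, compound 1 gives 5100 nM, and this is the only plain number in the set. Compound 2, `C#Cc1cccc(Nc2ncnc3cc(NC(=O)c4ccc(C(=O)Nc5ccccc5N)nc4)ccc23)c1`, is recorded in this assay only as a limit of the assay, > 50000 nM, so no number is known for it. This sits at the limit of > 50000 nM in this assay, at which 1 of the 2 values shown sits. Compound 3, `C#Cc1cccc(Nc2ncnc3ccc(OCc4ccc(C(=O)Nc5ccccc5N)cc4)cc23)c1`, has not yet been measured in this assay. It differs from compound 1 in one place: ethynyl in place of bromo on an aromatic carbon. Both groups sit on an aromatic carbon of a six-membered aromatic ring of carbon only, and both are small. Among the measured compounds shown here, no measured pair in this study shares that change. The expected step is a 1.3-fold lower number from compound 1 to compound 3 (0.11 log units; within the scatter), a shift no larger than the scatter of repeated measurements, leaning if anything toward a slight gain. For compound 3 the estimate in this assay is 4000 nM, with a range from 1500 nM to 12000 nM.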

Compound 3, half-maximal inhibitory concentration: 3400 nM
For compound 3 the middle estimate is 1.2-fold (0.07 log units) above the measured one, and the stated range covers the measured number.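

In this assay, the swap at this position gives a 1.5-fold lower number from compound 1 to compound 3 (0.18 log units; within the scatter) and so does not move the number by more than repeated measurements of the same compound would. Among these compounds, this is the first direct reading of this position, which the earlier compounds could not give, as no measured pair yet differed only here: a single bromine atom on the ring of the (3-bromophenyl)amino group gives way to the two carbons and the triple bond of an ethynyl group, and this assay does not tell the two apart. Among the compounds shown here, nothing measured so far offers an explanation for why the two groups read alike, and the one limit on record does not bear on this pair.

From the compounds shown here alone, it stays open whether a group of another kind on this aromatic carbon, such as an amine, a carboxylic acid or a longer chain like propyl, would shift the number beyond the scatter. A single pair also cannot say whether the same swap would give an equally small step in a compound that differs elsewhere.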